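This account rests on a few compounds, and the source may have more. Where it says the series, first, only, none or still open, it means among the compounds named here.

Of the compounds shown here, three built on one shared core have been tested in a functional assay on L1210 cells (Mus musculus) for inhibition, read by MTT assay, with a stated time of 72 h; on this read-out higher numbers stand for weaker inhibition and lower numbers for stronger inhibition. Compound 1 `COc1cc(NC(C)CCCNC(=O)NNC(=O)Nc2ccc(Br)cc2)c2ncccc2c1` gives 51000 nM, compound 2 `COc1cc(NC(C)CCCNC(=O)NNC(=O)Nc2cccc(C(F)(F)F)c2)c2ncccc2c1` gives 4000 nM, and compound 3 `COc1cc(NC(C)CCCNC(=O)Nc2cccc(Cl)c2)c2ncccc2c1` gives 17000 nM. Within the data shown here, of these three numbers compound 3 holds the second highest: the one measured step leading to it is a 3.0-fold lower number from compound 1 to compound 3 (0.48 log units; beyond the scatter), and compound 2, the furthest away, shows the lowest number of the three.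

Compound 4 `COc1cc(NC(C)CCCNC(=O)NNC(=O)Nc2ccc(Cl)cc2)c2ncccc2c1` has not yet been measured. It differs from compound 3 in a single place: ((4-chlorophenyl)carbamoyl)amino in place of 3-chlorophenyl on an amide-type nitrogen. The measured step that bears on this change runs the opposite way, a 3.0-fold lower number from compound 1 to compound 3 (0.48 log units; beyond the scatter), where a ((4-bromophenyl)carbamoyl)amino group gave way to 3-chlorophenyl and the number fell. Reversing that change points to a higher number for compound 4. The step of a 13-fold lower number from compound 1 to compound 2 (1.11 log units; beyond the scatter) shows that the ring carried on this group can move the number a great deal, so the uncertainty is wide. Compound 4 is therefore expected to give 40000 nM, with a range from 13000 nM to 120000 nM. The expected step is a 2.4-fold higher number from compound 3 to compound 4 (0.37 log units; beyond the scatter).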

Compound 4, half-maximal inhibitory concentration: 58000 nM
Beside the measured number, compound 4's estimate is 1.5-fold (0.16 log units) below it, within the range that was stated.
By their numbers in this assay, from the lowest: compound 2; then compound 3; then compounds 1 and 4 (each within the scatter of the next).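

In this assay chloro in place of bromo on an aromatic carbon leaves the reading unmoved (a 1.1-fold higher number from compound 1 to compound 4 (0.06 log units; within the scatter)), so at this position these two groups cannot be told apart. The large gap to the 3-(trifluoromethyl)phenyl compound therefore holds with chloro as it did with bromo (a 15-fold higher number from compound 2 to compound 4 (1.16 log units; beyond the scatter)). The step from the shorter group is also confirmed with a second halogen: ((4-chlorophenyl)carbamoyl)amino in place of 3-chlorophenyl gives a 3.4-fold higher number from compound 3 to compound 4 (0.53 log units; beyond the scatter), in the same direction as the step seen with bromo.

Nothing available explains these steps. From the compounds shown here alone, it stays open whether the gain with compound 2 comes from the trifluoromethyl group or from where it sits on the ring, which a 4-(trifluoromethyl)phenyl or 3-chlorophenyl group on this same longer chain could separate, and what an amine on that ring would do.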